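Adding a Side Chain to the Fused Ring of Compound 2

This account rests on a few compounds, and the source may have more. Where it says the series, first, only, none or still open, it means among the compounds named here.

Measured so far in an assay on isolated protein for inhibition of Gonadotropin-releasing hormone receptor (Rattus norvegicus); a higher number here means a weaker inhibitor, a lower number a stronger inhibitor:
compound 1 `CCn1c(SCc2cc([N+](=O)[O-])ccc2OC)nc2cc(NC(=O)NC(C)(C)C)ccc21` gives 170 nM
compound 2 `CCCn1c(SCc2cc([N+](=O)[O-])ccc2OC)nc2cc(NC(=O)NC(C)(C)C)ccc21` gives 120 nM
compound 3 `COc1ccc([N+](=O)[O-])cc1CSc1nc2cc(NC(=O)NC(C)(C)C)ccc2n1Cc1cccnc1` gives 150 nM

Compound 2 has the lowest of the three numbers, but its separation from the others is slight: a 1.4-fold lower number from compound 1 to compound 2 (0.15 log units; within the scatter) and a 1.3-fold higher number from compound 2 to compound 3 (0.10 log units; within the scatter) both lie within the scatter, as does a 1.1-fold lower number from compound 1 to compound 3 (0.05 log units; within the scatter). Compound 4 `CCCn1c(SCc2cc([N+](=O)[O-])ccc2OC)nc2cc(NC(=O)NC(C)(C)C)cc(C(=O)NCCCN(C)C)c21` keeps everything of compound 2 and differs in one place: (3-(dimethylamino)propyl)carbamoyl in place of hydrogen on an aromatic carbon. Among the measured compounds shown here, none of the measured steps touches this position; all three concern only the group on the aromatic nitrogen, and none moved the number beyond the scatter. They therefore give no guide to the size or direction of the change at this position, and the estimate is uncertain. The step is estimated as a 1.3-fold higher number from compound 2 to compound 4 (0.10 log units; within the scatter). Compound 4 is estimated at 150 nM, within a range of 40 nM to 600 nM.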

Compound 4, half-maximal inhibitory concentration: 19 nM
Beside the measured number, compound 4's estimate is 7.9-fold (0.90 log units) above it; the measured number lies below the stated range.
By their numbers in this assay, from the lowest: compound 4; then compounds 2, 3 and 1 (each within the scatter of the next).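

In this assay, (3-(dimethylamino)propyl)carbamoyl in place of hydrogen on this aromatic carbon gives a 6.3-fold lower number from compound 2 to compound 4 (0.80 log units; beyond the scatter), the only step shown that lies beyond the scatter. Among the compounds shown here, the earlier steps all concerned the group on the aromatic nitrogen, so this is the first sign that the number responds to a change elsewhere on the core. Nothing shown bears on why the number falls.

Open, as far as these compounds go, is whether the step needs the terminal dimethylamino group, which a simple methyl amide, a primary amine on the same chain or a carboxylic acid at this carbon would test. Also open, from the compounds shown here alone, is whether the same step appears with the ethyl group of compound 1 on the aromatic nitrogen.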